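This account rests on a few compounds, and the source may have more. Where it says the series, first, only, none or still open, it means among the compounds named here.

Among the compounds with values here, the three compounds measured so far share one core. Compound 1 `CCCOC(=O)C1=C(C)NC(=O)NC1c1cccs1` gives 43% in an assay on membranes from CHO cells for displacement of a labelled ligand from adenosine receptor A1 (Homo sapiens), read by scintillation counting, with a stated time of 60 min, tested at 1 uM; on this read-out higher numbers stand for more inhibition at the one concentration tested (going by the name of the read-out) and lower numbers for less inhibition. Compound 2 `COC(=O)C1=C(C)N(C)C(=O)NC1c1cccs1` gives 30% in this assay, and compound 3 `CCCOC(=O)C1=C(C)N(C)C(=O)NC1c1cccs1` gives 9% in this assay. Compound 3 thus stands lowest of the three: the nearest number belongs to compound 2, with a number 21 percentage points lower from compound 2 to compound 3 (beyond the scatter), and the furthest to compound 1, with a number 34 percentage points lower from compound 1 to compound 3 (beyond the scatter).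

Compound 4 `CC1=C(C(=O)OCc2ccccc2)C(c2cccs2)NC(=O)N1C` has not yet been measured. It differs from compound 3 in one place: phenyl in place of ethyl on a saturated chain carbon bound to an oxygen next to a carbonyl group. Within the data shown here, of the measured steps, only the one from compound 2 to compound 3 touches this same place, a saturated chain carbon bound to an oxygen next to a carbonyl group, and there a larger group brought a number 21 percentage points lower from compound 2 to compound 3 (beyond the scatter). Compound 3 already sits close to the bottom of the scale, so the expected step of a number 2 percentage points lower from compound 3 to compound 4 (within the scatter) is small or none beyond the scatter, if anything downward. Compound 4 is therefore estimated at 7% in this assay, within a range from 0% to 25%.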

Compound 4, a percentage reported as inhibition, at one concentration (the size of the read-out at that concentration, not a potency): 50%
Compound 4: the middle estimate sits 43 percentage points below what was measured; the whole stated range lies below it.
By their numbers in this assay, from the lowest: compound 3; then compound 2; then compounds 1 and 4 (each within the scatter of the next).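

At this place, on a saturated chain carbon bound to an oxygen next to a carbonyl group, the result depends on which group enters and not simply on adding atoms: in this assay, ethyl in place of hydrogen gave a number 21 percentage points lower from compound 2 to compound 3 (beyond the scatter), while phenyl in place of ethyl gave a number 41 percentage points higher from compound 3 to compound 4 (beyond the scatter). Phenyl in place of hydrogen gave a number 20 percentage points higher from compound 2 to compound 4 (beyond the scatter), so among these three compounds the number does not fall steadily as the group grows, and the low value belongs to the ethyl compound alone. Nothing available explains why phenyl raises the number here. Still open, from the compounds shown here alone, is whether the aromatic ring itself matters, which a cyclohexyl ring or a longer chain such as butyl at this place could help to settle. Also open, going by these compounds, is whether phenyl gives a similar step when the amide hydrogen replaces the methyl on the ring nitrogen.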